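This account rests on a few compounds, and the source may have more. Where it says the series, first, only, none or still open, it means among the compounds named here.

Compounds measured so far in an assay for inhibition of Alpha amylase (Homo sapiens), with a stated time of 10 min; on this read-out higher numbers stand for weaker inhibition and lower numbers for stronger inhibition:

Compound 1, `Oc1ccc(/C=N/n2cnnc2)cc1`: 2990 nM
Compound 2, `Oc1ccc(/C=N/n2cnnc2)cc1O`: 5690 nM
Compound 3, `COc1cc(/C=N/n2cnnc2)ccc1O`: 5940 nM

Compound 3 carries the higher of the three numbers, but the gaps to its neighbours are small: a 2.0-fold higher number from compound 1 to compound 3 (0.30 log units; within the scatter) and a 1.0-fold higher number from compound 2 to compound 3 (0.02 log units; within the scatter) both fall within the scatter, so the three measured compounds cannot be told apart on this read-out.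

Compound 4, `Oc1ccc(/C=N/n2cnnc2)cc1Br`, has not yet been measured. The change from compound 3 is bromo in place of methoxy on an aromatic carbon. Among the compounds with values here, two measured steps touch the same position of the shared core: the methoxy entering in place of hydrogen, a 2.0-fold higher number from compound 1 to compound 3 (0.30 log units; within the scatter), and the methyl added to the oxygen, a 1.0-fold higher number from compound 2 to compound 3 (0.02 log units; within the scatter). Neither moved the number beyond the scatter, so the data give no sign that a group at this position changes the outcome in this assay. Within the data shown here, with no step of size to lean on, compound 4 is expected to land close to compound 3, at an estimated 4500 nM, within a range of 1800 nM to 11000 nM. The step this estimate implies, a 1.3-fold lower number from compound 3 to compound 4 (0.12 log units; within the scatter), is expected to stay within the scatter.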

Compound 4, half-maximal inhibitory concentration: 2270 nM
For compound 4 the middle estimate is 2.0-fold (0.30 log units) above the measured one; low and high end bracket the measured number.
By their numbers in this assay, from the lowest: compounds 4, 1, 2 and 3 (each within the scatter of the next, the first and the last beyond it).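

In this assay, within the data shown here, this position shows steps beyond the scatter for the first time: bromo in place of methoxy gives a 2.6-fold lower number from compound 3 to compound 4 (0.42 log units; beyond the scatter) and bromo in place of hydroxy gives a 2.5-fold lower number from compound 2 to compound 4 (0.40 log units; beyond the scatter), both modest. Bromo in place of hydrogen stays within the scatter (a 1.3-fold lower number from compound 1 to compound 4 (0.12 log units; within the scatter)), so compound 1 and compound 4 cannot be told apart, and the group at this position separates compounds only when bromo is compared with hydroxy or methoxy. Nothing available accounts for these differences.

The compounds shown leave open whether other groups at this position, such as chloro, an amine or a carboxylic acid, would move the number beyond the scatter relative to hydrogen. They also leave open whether bromo would behave alike without the hydroxy group on the same ring.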